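The compounds below may be only part of what the source reports. "The series", "measured", "known", "first", "only" and "open" are said of these compounds alone.

Compound 1 `Cc1nc(SCC(=O)Nc2nc(-c3ccc(Cl)cc3)cs2)n(Nc2ccccc2)c1C` was tested in a functional assay on UACC-257 cells (Homo sapiens) for antiproliferative activity, read by sulforhodamine B assay, with a stated time of 48 h (a lower number here means a stronger inhibitor of growth, a higher number a weaker inhibitor of growth), and gave 3070 nM there. Its neighbour in the same series, compound 2 `Cc1ccc(Nn2c(SCC(=O)Nc3nc(-c4ccccc4)cs3)nc(C)c2C)cc1`, gave 2120 nM in this assay. Among the measured compounds shown here, of the two numbers so far, compound 1 has the higher one, but its gap to compound 2 is within the usual scatter of such measurements, so the two values cannot be told apart with any confidence.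

The step to be followed leads from compound 1 to compound 3 `COc1ccc(Nn2c(SCC(=O)Nc3nc(-c4ccc(Cl)cc4)cs3)nc(C)c2C)cc1`. The change is small: methoxy in place of hydrogen on an aromatic carbon. For the measured compounds named here, no measured pair in this set shows the effect of such a change, so there is nothing here to anchor a direction. Since the two values known sit so close to each other, the expectation for the step from compound 1 to compound 3 in this assay is one of no change beyond the scatter, amounting to a 1.2-fold lower number from compound 1 to compound 3 (0.07 log units; within the scatter). Compound 3 is accordingly estimated at 2600 nM, with a range from 1000 nM to 7000 nM.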

Compound 3, concentration for 50% growth inhibition: 2970 nM
Estimate against measurement, compound 3: 1.1-fold (0.06 log units) below; the range from low to high includes it.
By their numbers in this assay, from the lowest: compounds 2, 3 and 1 (each within the scatter of the next).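

Among the compounds shown here, this is the first reading of the aromatic carbon para to a large group on its own, since compound 1 and compound 2 differ in more than one place and so could not isolate any single position. In this assay, methoxy in place of hydrogen at this carbon gives a 1.0-fold lower number from compound 1 to compound 3 (0.01 log units; within the scatter) and so leaves the growth-inhibition read-out indistinguishable from that of the parent, which shows that, for this one pair, phenyl to 4-methoxyphenyl brings no measurable difference. No measured property of these compounds offers an explanation for this result.

Going by these compounds, whether an amine, a carboxylic acid or a longer chain such as butoxy on the same aromatic carbon would give a number beyond the scatter remains open, and a single pair cannot say whether hydrogen and methoxy are interchangeable there more generally. On these data alone, it is equally open whether methoxy at this carbon would read the same way on a compound that carries a different group elsewhere on the shared core.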